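A few compounds are considered here, and "the series" means these few. Any claim that something is new, unique, unknown or untested is made for them only; others in the source may bear on it.

Compound 2 `CNC(=O)c1cc(S(=O)(=O)N2CCS[C@H]2C(=O)O[C@@H](Cc2c(Cl)c[n+]([O-])cc2Cl)c2ccc(OC(F)F)c(OCC3CC3)c2)cn1C` is a sulfonamide ester carrying a dichloropyridine N-oxide; in an ADME assay on Caco-2 cells (Homo sapiens) for permeability, read by LC-MS, in the apical to basolateral direction, with a stated time of 2 h, tested at 10 uM (on this read-out higher numbers stand for higher permeability and lower numbers for lower permeability), compound 2 gives 12.6 nm/s. For the measured compounds named here, this is the lower of the two numbers known so far. The other one belongs to compound 1 `CN(C)C(=O)c1cccc(S(=O)(=O)N2CSC[C@H]2C(=O)O[C@@H](Cc2c(Cl)c[n+]([O-])cc2Cl)c2ccc(OC(F)F)c(OCC3CC3)c2)c1`, which in this assay gives 28 nm/s, a value that lies beyond the usual scatter above that of compound 2. Compound 3 `Cn1cnc(S(=O)(=O)N2CCS[C@H]2C(=O)O[C@@H](Cc2c(Cl)c[n+]([O-])cc2Cl)c2ccc(OC(F)F)c(OCC3CC3)c2)c1` has not yet been measured. Compared with compound 2, it carries a 1-methyl-1H-imidazol-4-yl on the sulfonyl sulfur in place of the larger group, as counted here: a group of 6 heavy atoms (4 carbon, 2 nitrogen; one five-membered aromatic ring with 2 hetero atoms) in place of a group of 10 heavy atoms (7 carbon, 2 nitrogen, 1 oxygen; one five-membered aromatic ring with 1 hetero atom), on a sulfonyl sulfur. Going by the values given here, no step between measured compounds matches this change, so the expectation rests on the two numbers alone. A modest rise is expected, a 2.0-fold higher number from compound 2 to compound 3 (0.30 log units; within the scatter), taking compound 3 no further than the region around compound 1. Compound 3 is thus estimated at 25 nm/s in this assay, with a likely range from 10 nm/s to 60 nm/s.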

Compound 3, apparent permeability: 2.2 nm/s
Compound 3: the middle estimate sits 11-fold (1.06 log units) above what was measured; measured number outside the range, below it.
By their numbers in this assay, from the lowest: compound 3; then compound 2; then compound 1.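

Placing 1-methyl-1H-imidazol-4-yl on the sulfonyl sulfur in place of the larger group of 10 heavy atoms gives, in this assay, a 5.7-fold lower number from compound 2 to compound 3 (0.76 log units; beyond the scatter) and so shows that this read-out responds to what sits at this position. The smaller group did not raise the number here, and the change in heavy atoms, ring type and hydrogen-bond donors arrives as one step, so these differences cannot be told apart. No measurement offered here accounts for the fall.

The compounds shown leave open whether the fall follows the imidazole ring or the loss of the amide carbonyl and its hydrogen. They also leave open how a plain phenyl or a carboxylic acid on the sulfonyl sulfur would read.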